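This account rests on a few compounds, and the source may have more. Where it says the series, first, only, none or still open, it means among the compounds named here.

Measured in a functional assay on the whole organism for inhibition, with Scenedesmus acutus as the target; a higher number here means a weaker inhibitor, a lower number a stronger inhibitor:

Compound 1 `CCOC(=O)c1cc(N2C(=O)C3=C(CCCC3)C2=O)c(F)cc1Cl`: 57.5 nM
Compound 2 `CCOC(=O)c1cc(N2C(=O)C3=C(CCCC3)C2=O)ccc1Cl`: 1910 nM

For the measured compounds named here, compound 1 holds the lower of these two numbers, and so far compound 2 is its only measured neighbour. Going by the values given here, the single measured step, a 33-fold higher number from compound 1 to compound 2 (1.52 log units; beyond the scatter), comes with hydrogen in place of fluoro on an aromatic carbon.

Compound 3 `CC(C)OC(=O)c1cc(N2C(=O)C3=C(CCCC3)C2=O)c(F)cc1Cl` keeps the core of compound 1 and differs only in its side chain, where ethoxycarbonyl becomes isopropoxycarbonyl: methyl in place of hydrogen on a saturated chain carbon bound to an oxygen next to a carbonyl group and a saturated chain carbon.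

Among the compounds with values here, no measured step touches this place, since the only one available concerns the aromatic carbon. It therefore gives no direct guide to the size or direction of the new change. With nothing measured at this place, no step beyond the scatter is expected in this assay, and no firm direction can be given. The expected step is a 1.2-fold higher number from compound 1 to compound 3 (0.09 log units; within the scatter). The range is nevertheless kept wide because of a 33-fold higher number from compound 1 to compound 2 (1.52 log units; beyond the scatter), which shows how far one small change can move the number in this pair. Compound 3 is estimated at 70 nM, with an expected range from 20 nM to 250 nM.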

Compound 3, half-maximal inhibitory concentration: 13.8 nM
Compound 3: middle estimate off by 5.1-fold (0.71 log units), on the high side; measured number below the stated range.
By their numbers in this assay, from the lowest: compound 3; then compound 1; then compound 2.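

In this assay, the ester side chain turns out to be a place where the number responds: going from ethoxycarbonyl to isopropoxycarbonyl gives a 4.2-fold lower number from compound 1 to compound 3 (0.62 log units; beyond the scatter), so one added methyl on the saturated chain carbon bound to the oxygen is enough to move the number beyond the scatter, towards a stronger inhibitor. For the compounds shown here, the earlier compounds showed only the step at the aromatic carbon, a 33-fold higher number from compound 1 to compound 2 (1.52 log units; beyond the scatter), where the change from fluoro to hydrogen raised the number; this new step lies at a different place, runs the other way and is smaller in size. Nothing available here bears on the reason for the lower number with the added methyl.

As far as these compounds go, whether the number keeps falling as this side chain grows remains open, and a tert-butyl ester, a longer chain such as n-propyl, or a free carboxylic acid in place of the ester would each speak to that. From the compounds shown here alone, the isopropoxycarbonyl group also appears here only together with the fluoro group, and whether its step holds with hydrogen on that aromatic carbon is still unknown.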